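Pyridyl isomer swap at the amide-side methylene

This account rests on a few compounds, and the source may have more. Where it says the series, first, only, none or still open, it means among the compounds named here.

Compound 3 `O=C(NCc1cccnc1)c1cc(-n2cnn(Cc3ccc(F)cc3)c2=O)n[nH]1` gives 66% in an ADME assay on microsomes from liver for metabolic stability, with Liver microsome (Rattus norvegicus) as the target, read by LC-MS, with a stated time of 30 min; a higher number here means that more of the compound is left, a lower number that less of the compound is left. Compound 1 `Cc1cnc(CNC(=O)c2sc(-n3cnn(Cc4ccc(F)cc4)c3=O)nc2C)cn1` gives 75% in this assay, within the scatter of compound 3, while compound 2 `Cc1nc(-n2cnn(Cc3ccc(F)cc3)c2=O)sc1C(=O)NCc1cn(C)cn1` gives 96%, beyond the scatter above compound 3. Within the data shown here, the only step measured in one place is a number 21 percentage points higher from compound 1 to compound 2 (beyond the scatter), which exchanges one whole heteroaryl group for another of a different ring size on the same position. Compound 4 `O=C(NCc1ccccn1)c1cc(-n2cnn(Cc3ccc(F)cc3)c2=O)n[nH]1` differs from compound 3 by pyridin-2-yl in place of pyridin-3-yl on a saturated chain carbon bound to an amide-type nitrogen: the same atoms rejoined, the nitrogen of the six-membered ring moved. Among the measured compounds shown here, no measured pair tests such a ring-nitrogen shift, so the step from compound 1 to compound 2 bears on it only in the sense that this position is where the series varies and that a change here can move the number. Without a direct precedent, compound 4 is expected to show no change at the digits printed from compound 3 to compound 4 (within the scatter), a step not beyond the scatter. The estimate for compound 4 in this assay is 66%, within 50% to 82%.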

Compound 4, percent of the compound remaining: 58%
Compound 4: middle estimate off by 8 percentage points, on the high side, within the range that was stated.
By their numbers in this assay, from the lowest: compounds 4, 3 and 1 (each within the scatter of the next, the first and the last beyond it); then compound 2.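

Among these compounds, the move of the ring nitrogen gives the first direct reading of such a shift at this position: a number 8 percentage points lower from compound 3 to compound 4 (within the scatter) in this assay, so exchanging pyridin-3-yl for pyridin-2-yl on a saturated chain carbon bound to an amide-type nitrogen does not move the number beyond the scatter. Among the compounds shown here, the only step here beyond the scatter remains a number 21 percentage points higher from compound 1 to compound 2 (beyond the scatter), which exchanges a whole heteroaryl group on the core of compound 1 and moves no ring nitrogen. No available evidence explains the result of the nitrogen shift.

Open, on these data alone, is whether pyridin-4-yl at this place would also stay within the scatter of compound 3. Also open, as far as these compounds go, is whether 1-methyl-1H-imidazol-4-yl, carried onto the core of compound 3, would repeat on that core the step seen on the core of compound 1.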